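A few compounds are considered here, and "the series" means these few. Any claim that something is new, unique, unknown or untested is made for them only; others in the source may bear on it.

Among the measured compounds shown here, compound 1 `CCN(CC)c1ccc(C(F)(F)F)cc1NC(=O)c1cccnc1` is the only compound of this small set that carries a single number: in a functional assay on HL-60 cells (Homo sapiens) for cytotoxicity, read by MTT assay, with a stated time of 48 h (on this read-out lower numbers stand for stronger inhibition and higher numbers for weaker inhibition), compound 1 gives 71000 nM, a weak effect. Compound 2 `O=C(Nc1cc(C(F)(F)F)ccc1N1CCCC1)c1cccnc1` is recorded in this assay as "not active" (no number reported), with no number given. Compound 3 `CCN(CC)c1ccc(C(F)(F)F)cc1NC(=O)c1cccnc1Cl` differs from compound 1 by chloro in place of hydrogen on an aromatic carbon. For the measured compounds named here, no measured pair shows what this change does here, so the step is expected to stay within the usual scatter, in no clear direction: a 1.3-fold lower number from compound 1 to compound 3 (0.11 log units; within the scatter). Compound 3 is therefore estimated at 55000 nM, between 15000 nM and 150000 nM.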

Compound 3, half-maximal inhibitory concentration: 84100 nM
Compound 3: the middle estimate sits 1.5-fold (0.18 log units) below what was measured, and the stated range covers the measured number.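

In this assay, chloro in place of hydrogen next to the ring nitrogen amounts to a 1.2-fold higher number from compound 1 to compound 3 (0.07 log units; within the scatter) and so leaves the read-out where it stood, showing that this position takes a chlorine atom without a clear shift in the weak effect. Nothing at hand bears on why this is so. The compounds shown leave open whether an amine, a methoxy group or a carboxylic acid at this same position would move the number. They also leave open whether chloro would act alike on the core of compound 2.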